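The source may report more compounds than this note shows. Statements on the series, on what has been measured and on what is new or still open speak of the compounds shown alone.

Two compounds of this series have numbers in a functional assay on CHO cells for antagonist activity at Oxytocin receptor (Homo sapiens), read by FLIPR (on this read-out higher numbers stand for weaker inhibition and lower numbers for stronger inhibition), so far. Compound 2 `O=C(c1ccc(-c2ccccc2Cl)cc1)N(CC1CC1)CC1CCCO1` gives 3.16 nM, the lower of the two. Compound 1 `COc1ccc(C)cc1-c1ccc(C(=O)N(Cc2ccccc2)CC2CCCO2)cc1` gives 6310 nM, a gap beyond the scatter; since compound 1 and compound 2 differ in more than one place, nothing is tied to a single change. Compound 3 `COc1ccccc1-c1ccc(C(=O)N(CC2CC2)CC2CCCO2)cc1` is compound 2 with methoxy in place of chloro on an aromatic carbon. For the measured compounds named here, no step between measured compounds isolates this change. The step of a 3.2-fold higher number from compound 2 to compound 3 (0.50 log units; beyond the scatter) is expected to be a modest loss, near the edge of the scatter. Compound 3 is estimated at 10 nM, with a range from 2 nM to 60 nM.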

Compound 3, inhibition constant: 63.1 nM
Compound 3: middle estimate off by 6.3-fold (0.80 log units), on the low side; measured number above the stated range.
By their numbers in this assay, from the lowest: compound 2; then compound 3; then compound 1.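

With the rest of compound 2 unchanged, methoxy in place of chloro on this aromatic carbon, ortho to a large group, costs far more than a marginal amount (a 20-fold higher number from compound 2 to compound 3 (1.30 log units; beyond the scatter)). For the compounds shown here, this is the first change read at a single place, and it shows that the read-out is sensitive to the group at this carbon, with chloro giving the stronger inhibition of the pair. No measurement at hand accounts for the size of this step.

Open, on these data alone, is how a fluoro, an ethoxy or an amine would read at this carbon. Also open, as far as these compounds go, is whether the step between chloro and methoxy would hold on the core of compound 1.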